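This account rests on a few compounds, and the source may have more. Where it says the series, first, only, none or still open, it means among the compounds named here.

Three related compounds have so far been measured in an ADME assay on microsomes from liver (Homo sapiens) for metabolic stability, tested at 2.5 uM; a lower number here means slower removal, a higher number faster removal of the compound. Compound 1 `O=S(=O)(c1ccc(F)cc1)c1cnc2cc(Cl)c(F)cc2c1-c1ccc(Cl)cc1` gives 0.01 mL/min, the lowest of the three numbers. Compound 2 `O=S(=O)(c1ccc(F)c(Cl)c1)c1cnc2c(F)cccc2c1-c1ccccc1F` gives 1.39 mL/min, and compound 3 `COc1ccc(S(=O)(=O)c2cnc3cc(F)ccc3c2-c2ccc(F)cc2)cc1Cl` gives 1.29 mL/min; both lie far above compound 1, well beyond the usual scatter of repeated measurements, with compound 3 the nearer of the two. Compound 4 `O=S(=O)(c1ccc(F)cc1)c1cnc2cc(Cl)ccc2c1-c1ccc(Cl)cc1` has not been measured yet. It differs from compound 1 in one place: hydrogen in place of fluoro on an aromatic carbon. Going by the values given here, no measured pair shows this exact change, so the direction rests only on the numbers already seen, which run much higher for compound 2 and compound 3. A modest rise toward faster removal is expected, a 5.0-fold higher number from compound 1 to compound 4 (0.70 log units; beyond the scatter), though a result within the scatter remains possible. Compound 4 is therefore estimated at 0.05 mL/min, with a likely range from 0.01 mL/min to 0.4 mL/min.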

Compound 4, intrinsic clearance in a liver preparation (reported as CLH), per the amount of preparation that the assay uses: 0.21 mL/min
Estimate against measurement, compound 4: 4.2-fold (0.62 log units) below; low and high end bracket the measured number.
By their numbers in this assay, from the lowest: compound 1; then compound 4; then compounds 3 and 2 (each within the scatter of the next).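

In this assay, going by these compounds alone, putting hydrogen in place of fluoro on this aromatic carbon, ortho to a chloro group, gives a 21-fold higher number from compound 1 to compound 4 (1.32 log units; beyond the scatter) and provides the first comparison of compounds that differ in one place. A single atom at this position is therefore enough to move the number well beyond the scatter, so the very low number of compound 1 depends on the fluoro group here. Nothing available explains why this change has so large an effect. Going by these compounds, whether other groups at this carbon, such as a nitrile or an amine, would keep the number low remains open. So does whether the same change elsewhere on the shared core would produce a step of similar size.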